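This account rests on a few compounds, and the source may have more. Where it says the series, first, only, none or still open, it means among the compounds named here.

Compound 1 `CCCc1nnc(O)n2c(C)ncc12` gives > 48000 nM in a functional assay for inhibition, with Homo sapiens as the target (a lower number here means a stronger inhibitor, a higher number a weaker inhibitor), which is a limit of the assay and not a number.
Compound 2 `Cc1ncc2cnnc(O)n12` gives > 48000 nM in this assay, again a limit.
Compound 3 `CSc1nncc2cnc(C)n12` gives > 48000 nM in this assay, again a limit.

Compound 2 therefore stands only at a limit, and the same holds for the other two, as the limit of > 48000 nM in this assay, at which 3 of the 3 values shown sit, shows. The step that the two limits leave unreadable from compound 1 to compound 2 and the step that the two limits leave unreadable from compound 2 to compound 3 each run from one limit to another, so their size cannot be read. Compound 4 `CC(C)(C)c1ncc2cnnc(O)n12` differs from compound 2 by tert-butyl in place of methyl on an aromatic carbon. Going by the values given here, no measured step of readable size bears on this change. Because all three values sit at the limit of > 48000 nM in this assay, at which 3 of the 3 values shown sit, the step that the limit leaves unreadable from compound 2 to compound 4 expected for compound 4 is itself unreadable, and compound 4 is expected to stay at the limit. Compound 4 is estimated at 80000 nM, in a range from 20000 nM to 300000 nM.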

Compound 4, half-maximal inhibitory concentration: > 48000 nM
Compound 4: no number, only a limit; the forecaster's own chance of this, stated with the estimate: 85%; the middle value lies beyond the limit too.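

No step can be read from compound 2 to compound 4, because each of the two stands at a limit and not a number: the limit of > 48000 nM in this assay, at which 4 of the 4 values shown sit.
Which change to the shared core, if any, would give a readable value in this assay stays open.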